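Amide aryl variation on the shared core

The source may report more compounds than this note shows. Statements on the series, on what has been measured and on what is new or still open speak of the compounds shown alone.

Compound 1, `COc1cc(C(=O)Nc2ccc(C(=O)/C=C/c3nc(C)c(C)nc3C)cc2)cc(OC)c1OC`, in a functional assay on MCF7 cells (Homo sapiens) for antiproliferative activity, read by CCK-8 assay, with a stated time of 72 h; on this read-out higher numbers stand for weaker inhibition and lower numbers for stronger inhibition: 2760 nM
Compound 2, `Cc1nc(C)c(/C=C/C(=O)c2ccc(NC(=O)c3ccccc3F)cc2)nc1C`, in this assay: 1270 nM

Among the compounds with values here, of the two numbers so far, compound 2 gives the lowest; the gap to compound 1 lies beyond the usual scatter, so compound 2 reads as the stronger inhibitor of the pair. Within the data shown here, no pair of measured compounds differs in only one place, so no single-change step is known in this assay.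

Compound 3, `COc1ccc(C(=O)Nc2ccc(C(=O)/C=C/c3nc(C)c(C)nc3C)cc2)cc1OC`, is the next case. It differs from compound 2 by 3,4-dimethoxyphenyl in place of 2-fluorophenyl on a carbonyl carbon. The closest point of reference is compound 1, whose amide aryl also carries methoxy groups and which gives 2760 nM in this assay. On that basis the expected step of a 1.6-fold higher number from compound 2 to compound 3 (0.20 log units; within the scatter) is a moderate move towards a higher number, of a size near the edge of the scatter rather than clearly beyond it. For compound 3 the estimate in this assay is 2000 nM, with a range from 800 nM to 5000 nM, the upper part of that range covering the possibility that it lands close to compound 1.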

Compound 3, half-maximal inhibitory concentration: 1660 nM
For compound 3 the middle estimate is 1.2-fold (0.08 log units) above the measured one, and the stated range covers the measured number.
By their numbers in this assay, from the lowest: compounds 2, 3 and 1 (each within the scatter of the next, the first and the last beyond it).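

With 3,4-dimethoxyphenyl in place of 2-fluorophenyl on a carbonyl carbon whose other neighbour is an amide-type nitrogen, this assay gives a 1.3-fold higher number from compound 2 to compound 3 (0.12 log units; within the scatter) and so does not separate the two aryl groups, although they differ in their substituents and the entering group brings two hydrogen-bond acceptors. Within the data shown here, this is the first single-change reading at this position, and it shows that the position tolerates this exchange without a difference beyond the scatter. The second single-change reading, hydrogen in place of methoxy on an aromatic carbon, gives a 1.7-fold lower number from compound 1 to compound 3 (0.22 log units; within the scatter) and is also within the scatter, so compound 3 cannot be separated from compound 1 or from compound 2 even though those two stand beyond the scatter of each other. Nothing measured here accounts for these readings.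

Going by these compounds, whether an amine, a carboxylic acid or a longer alkoxy chain on the amide aryl ring would give a step beyond the scatter remains open. Also open, on these data alone, is how an unsubstituted phenyl at this carbonyl carbon would read against the fluoro and methoxy aryl groups in this assay on the shared core.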